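The source may report more compounds than this note shows. Statements on the series, on what has been measured and on what is new or still open speak of the compounds shown alone.

Measured in a physicochemical assay for solubility, with a stated time of 24 h, tested at 30 mg/mL; on this read-out lower numbers stand for lower solubility and higher numbers for higher solubility:
- Compound 1 `C[C@H](Nc1c(NCCCCCC(=O)NO)c(=O)c1=O)c1ccccc1`: 28000000 nM
- Compound 2 `Cc1cccc([C@@H](C)Nc2c(NCCCCCC(=O)NO)c(=O)c2=O)c1`: 82000000 nM
- Compound 3 `O=C(CCCCCNc1c(NC2CCCCC2)c(=O)c1=O)NO`: 8700000 nM

Compound 3 has the lowest number of the three. Compound 4 `Cc1ccc(Nc2c(NCCCCCC(=O)NO)c(=O)c2=O)cc1` has not yet been measured. It differs from compound 3 by one change: 4-methylphenyl in place of cyclohexyl on a nitrogen on an aromatic ring. In words, this is 4-methylphenyl in place of cyclohexyl on a nitrogen on an aromatic ring.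

Among the measured compounds shown here, only one measured step involves this place: a 3.2-fold lower number from compound 1 to compound 3 (0.51 log units; beyond the scatter). That step swaps cyclohexyl with 1-phenylethyl, not 4-methylphenyl, so it is only a loose guide. Read in reverse, it suggests a modest rise when cyclohexyl leaves, and a small rise is expected here, perhaps none beyond the scatter. The expected step is a 1.4-fold higher number from compound 3 to compound 4 (0.14 log units; within the scatter). The estimate for compound 4 is 12000000 nM, with an expected range of 3000000 nM to 45000000 nM.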

Compound 4, solubility: 1800000 nM
Beside the measured number, compound 4's estimate is 6.7-fold (0.82 log units) above it; measured number below the stated range.
By their numbers in this assay, from the lowest: compound 4; then compound 3; then compound 1; then compound 2.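

In this assay 4-methylphenyl on this nitrogen gives a 4.8-fold lower number from compound 3 to compound 4 (0.68 log units; beyond the scatter) when it replaces cyclohexyl, and a 16-fold lower number from compound 1 to compound 4 (1.19 log units; beyond the scatter) when it replaces 1-phenylethyl. Cyclohexyl and 4-methylphenyl both have no hydrogen-bond donors or acceptors and no net charge, yet the two compounds still differ beyond the scatter. Nothing available here explains this difference. The compounds shown leave open how an amine or a carboxylic acid on the ring at this position would change the number. They also leave open what role the methyl of 4-methylphenyl plays.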